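Compound 3 loses its (isopropylcarbonyl)oxy group

A few compounds are considered here, and "the series" means these few. Any claim that something is new, unique, unknown or untested is made for them only; others in the source may bear on it.

Among the measured compounds shown here, in an ADME assay on S9 fraction from liver (Rattus norvegicus), read by LC-MS, with a stated time of 60 min, at 37 degrees C (a higher number here means that more of the compound is left, a lower number that less of the compound is left), compound 3 `CC(OC(=O)C(C)C)OC(=O)N1CCN(C(=O)c2nc(Nc3cc(C4CC4)[nH]n3)c3cc(Cl)ccc3n2)C[C@H]1C` gives 11%, the lowest of the three numbers measured so far. Compound 1 `CC(C)COC(=O)N1CCN(C(=O)c2nc(Nc3cc(C4CC4)[nH]n3)c3cc(Cl)ccc3n2)C[C@H]1C` gives 61.1%, and compound 2 `C[C@@H]1CN(C(=O)c2nc(Nc3cc(C4CC4)[nH]n3)c3cc(Cl)ccc3n2)CCN1C(=O)OC(C)(C)C` gives 71.3%.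

The compound still to be measured, compound 4 `CC(C)OC(=O)N1CCN(C(=O)c2nc(Nc3cc(C4CC4)[nH]n3)c3cc(Cl)ccc3n2)C[C@H]1C`, differs from compound 3 in one place: methyl in place of (isopropylcarbonyl)oxy on a saturated chain carbon bound to an oxygen next to a carbonyl group and a saturated chain carbon. Methyl takes the place of (isopropylcarbonyl)oxy on a saturated chain carbon bound to an oxygen next to a carbonyl group and a saturated chain carbon. Read one bond further out, 1-((isopropylcarbonyl)oxy)ethyl becomes isopropyl.

Two large measured steps bear most directly on this change. Putting 1-((isopropylcarbonyl)oxy)ethyl in place of isobutyl gave a number 50.1 percentage points lower from compound 1 to compound 3 (beyond the scatter), and putting it in place of tert-butyl gave a number 60.3 percentage points lower from compound 2 to compound 3 (beyond the scatter). Exchanging isobutyl for tert-butyl gave only a modest step, a number 10.2 percentage points higher from compound 1 to compound 2 (beyond the scatter). Isopropyl, like isobutyl and tert-butyl, lacks the (isopropylcarbonyl)oxy group, so compound 4 is expected to land near compound 1 and compound 2 rather than near compound 3. A large rise is therefore expected in this assay, namely a number 54 percentage points higher from compound 3 to compound 4 (beyond the scatter). The estimate for compound 4 is 65%, with an expected range of 50% to 80%.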

Compound 4, percent of the compound remaining: 78.6%
For compound 4 the middle estimate is 13.6 percentage points below the measured one; the range from low to high includes it.
By their numbers in this assay, from the lowest: compound 3; then compound 1; then compounds 2 and 4 (each within the scatter of the next).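

In this assay, methyl in place of (isopropylcarbonyl)oxy on the saturated chain carbon gives a number 67.6 percentage points higher from compound 3 to compound 4 (beyond the scatter), a large step that ties the low number of compound 3 to this one group rather than to the branched carbon that carries it. The earlier steps shown here could not make this separation. They exchanged the whole 1-((isopropylcarbonyl)oxy)ethyl group. On the same oxygen, the simpler groups lie much closer together: hydrogen in place of methyl, which turns tert-butyl into isopropyl, gives a number 7.3 percentage points higher from compound 2 to compound 4 (within the scatter), so removing that methyl has no readable effect here. Isopropyl in place of isobutyl gives a number 17.5 percentage points higher from compound 1 to compound 4 (beyond the scatter), a modest step, which leaves isobutyl as the one simple group among these three whose number stands apart from the other two, though by far less than the step from compound 3.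

Nothing shown here gives a measured reason for any of these differences. Going by these compounds, whether an acetyloxy group or a carboxylic acid on that same saturated chain carbon would also give a low number stays open, as does how a longer chain in place of isopropyl would read.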